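The source may hold more compounds than are shown below. What is called first, only, known or untested is meant among the compounds shown, and "the series" means these compounds.

Working notes on the sulfonyl series

The compounds share one core and differ only in the group on the sulfonyl sulfur. Compound 1 `O=S(=O)(Nc1ccc(-c2nc3ccccc3o2)cc1)c1ccc(Cl)s1` carries 5-chlorothiophen-2-yl; in an assay on cells for inhibition of HSP60/HSP10 (Homo sapiens), with a stated time of 60 min (a lower number here means a stronger inhibitor, a higher number a weaker inhibitor), compound 1 gives 31000 nM. Compound 2 `O=S(=O)(Nc1ccc(-c2nc3ccccc3o2)cc1)c1ccccc1Cl` carries 2-chlorophenyl. In this assay compound 2 reaches only the limit of the assay, > 100000 nM, so no number is available for it. Compound 3 `O=S(=O)(Nc1ccc(-c2nc3ccccc3o2)cc1)c1cccc(O)c1` carries 3-hydroxyphenyl; in this assay compound 3 gives 62000 nM, the highest of the two numbers, but the step of a 2.0-fold higher number from compound 1 to compound 3 (0.30 log units; within the scatter) lies within the scatter, so compounds 1 and 3 cannot be ordered. The step of an at least 3.2-fold higher number from compound 1 to compound 2 (0.50 log units; beyond the scatter) is beyond the scatter and rests on (the limit of > 100000 nM in this assay, at which 1 of the 3 values shown sits). The step of an at least 1.6-fold lower number from compound 2 to compound 3 (0.20 log units; that floor lies within the scatter) has only a floor, and that floor lies within the scatter.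

Compound 4 `O=S(=O)(Nc1ccc(-c2nc3ccccc3o2)cc1)c1ccccc1F` differs from compound 3 by 2-fluorophenyl in place of 3-hydroxyphenyl on a sulfonyl sulfur. The nearest measured precedent is the move onto a 2-halophenyl, which in compound 2 ended at the limit, and the return from compound 2 to compound 3 gave only a floor. A 2-fluorophenyl is therefore expected to behave like the 2-chlorophenyl of compound 2 and to push the number up, possibly to the limit again. Compound 4 is estimated at 120000 nM, with a range from 40000 nM to 400000 nM. The expected step is a 1.9-fold higher number from compound 3 to compound 4 (0.29 log units; within the scatter).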

Compound 4, half-maximal inhibitory concentration: > 100000 nM
Compound 4 gave a limit, no number; the forecaster's own chance of this, stated with the estimate: 60%; the middle value lies beyond the limit too.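

With compound 4, a second 2-halophenyl group on the sulfonyl sulfur ends at a limit of this assay, so fluoro in place of chloro on an aromatic carbon does not bring a readable number, and the result at compound 2 no longer stands alone. Measured against the 5-chlorothiophen-2-yl group, the new change gives an at least 3.2-fold higher number from compound 1 to compound 4 (0.50 log units; beyond the scatter), whereas against the 3-hydroxyphenyl group it gives only an at least 1.6-fold higher number from compound 3 to compound 4 (0.20 log units; that floor lies within the scatter), so compound 4 is separated from compound 1 but not yet from compound 3. The step between compound 2 and compound 4 cannot be read, and every step into these two compounds is a floor set by the same ceiling: the limit of > 100000 nM in this assay, at which 2 of the 4 values shown sit.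

From the compounds shown here alone, how far compound 2 and compound 4 actually lie beyond that ceiling stays open, and so does whether they differ from each other at all. Also open is how an amine, a carboxylic acid or a longer chain on the sulfonyl sulfur would read in this assay, since the compounds shown carry only one thiophene and three substituted phenyl groups at this place.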